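Alkyl chain trimming in a small adenosine receptor series

The compounds below may be only part of what the source reports. "The series", "measured", "known", "first", "only" and "open" are said of these compounds alone.

Measured compounds:
compound 1 `CCCOC(=O)C1=C(C)N(C)C(=O)NC1c1cccs1` — 9%
compound 2 `CC1=C(C(=O)OCC(C)C)C(c2cccs2)NC(=O)N1C` — 9%
compound 3 `CCC(CC)OC(=O)C1=C(C)NC(=O)NC1c1ccoc1` — 17%

In an assay on membranes from CHO cells for displacement of a labelled ligand from adenosine receptor A1 (Homo sapiens), read by scintillation counting, with a stated time of 60 min, tested at 1 uM (on this read-out lower numbers stand for less inhibition and higher numbers for more inhibition at the one concentration tested (going by the name of the read-out)), compound 1 gives 9% and compound 2 gives 9%. The two differ by hydrogen in place of methyl on a saturated chain carbon bound to two saturated chain carbons and the step of no change at the digits printed from compound 2 to compound 1 (within the scatter). Compound 3, with its own core, gives 17% in this assay; it stands within the scatter of both compound 1 and compound 2, so no order among the three can be read. The difference between the core of compound 3 and the core of compound 2 is not broken down here.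

Compound 4 `CCC(C)OC(=O)C1=C(C)NC(=O)NC1c1ccoc1` is the unmeasured partner of compound 3. It differs from compound 3 by hydrogen in place of methyl on a saturated chain carbon, two bonds along the chain from an oxygen next to a carbonyl group. This is the same kind of change as that from compound 2 to compound 1, but not the same: there the hydrogen entered on a saturated chain carbon bound to two saturated chain carbons, here it enters on a saturated chain carbon two bonds along the chain from an oxygen next to a carbonyl group. Within the data shown here, only one measured example of this kind of change exists, and it reached no change.

Among the measured compounds shown here, compound 4 is therefore expected to sit close to compound 3, with an estimated step of a number 2 percentage points lower from compound 3 to compound 4 (within the scatter) in this assay, because no change at the digits printed from compound 2 to compound 1 (within the scatter) is the only measured guide and it showed nothing. Compound 4 is expected to give about 15% in this assay, most likely between 4% and 28%.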

Compound 4, a percentage reported as inhibition, at one concentration (the size of the read-out at that concentration, not a potency): 13%
Estimate against measurement, compound 4: 2 percentage points above; the measured number falls inside the stated range.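

Trimming the pentan-3-yl ester chain to sec-butyl, with hydrogen in place of methyl, gives in this assay a number 4 percentage points lower from compound 3 to compound 4 (within the scatter). Set beside the earlier trimming on the core of compound 2, this step shows no difference between the two cores: the same change on two cores in this assay, no change at the digits printed (within the scatter) from compound 2 to compound 1 and a number 4 percentage points lower (within the scatter) from compound 3 to compound 4, 4 percentage points apart, within the scatter of two such steps

So far, this hydrogen-for-methyl replacement on the ester chain has left the read-out within the scatter on both cores, but the two replacements sit at different places on their chains, and neither step is large enough to show that an effect carries from one core to the other; a shared absence of a measurable step is weaker evidence of transfer than a shared step beyond the scatter would be.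

The compounds shown leave open whether any ester chain in this series can move the inhibition beyond the scatter, since only short branched and unbranched alkyl chains appear here, and a longer chain, a benzyl ester or a carboxylic acid in their place would test this directly. They also leave open how these compounds would compare as potencies, as each number here is a reading at one concentration on a single receptor.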